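Aryl swap in compound 1: expected outcome for compound 4

The source may hold more compounds than are shown below. What is called first, only, known or untested is meant among the compounds shown, and "the series" means these compounds.

Measured in a functional assay on CCRF-CEM cells (Homo sapiens) for antiproliferative activity, read by MTT assay, with a stated time of 72 h, tested at 50 uM; a higher number here means a weaker effect of the compound at the concentration tested, a lower number a stronger effect:
compound 1 `COC(C(=O)OC(C)Cn1cnc2c1c(=O)n(C)c(=O)n2C)c1cccc2ccccc12` gives 87.9%
compound 2 `CC(Cn1cnc2c1c(=O)n(C)c(=O)n2C)OC(=O)Sc1ccccc1` gives 37.1%
compound 3 `CC(Cn1cnc2c1c(=O)n(C)c(=O)n2C)OCc1cn(-c2cccc3ccccc23)nn1` gives 67.7%

Compound 1 has the highest number of the three, meaning the weakest effect; compound 3 is its nearest neighbour and compound 2 the furthest, both beyond the scatter. Compound 4 `COC(C(=O)OC(C)Cn1cnc2c1c(=O)n(C)c(=O)n2C)c1ccc(C(C)(C)C)cc1` is not yet measured. It differs from compound 1 in one place: 4-(tert-butyl)phenyl in place of naphthalen-1-yl on a saturated chain carbon bound to a carbonyl carbon and an oxygen on a saturated carbon. Going by the values given here, no measured pair shows this kind of change, so its size is unknown. The groups match in heavy-atom count and lack donors and acceptors, so only a small step in this assay is expected, probably within the scatter and slightly downward if anything. Compound 4 is therefore estimated at 84%, within 66% to 100%. The expected step is a number 3.9 percentage points lower from compound 1 to compound 4 (within the scatter).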

Compound 4, a percentage reported as activity, at one concentration (the size of the read-out at that concentration, not a potency): 55.3%
Compound 4: the middle estimate sits 28.7 percentage points above what was measured, and the stated range ends above it.
By their numbers in this assay, from the lowest: compound 2; then compound 4; then compound 3; then compound 1.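

In this assay, the swap of naphthalen-1-yl for 4-(tert-butyl)phenyl gives a number 32.6 percentage points lower from compound 1 to compound 4 (beyond the scatter). This position is therefore sensitive to which aryl group it carries, even though both groups have the same heavy-atom count and neither has hydrogen-bond donors or acceptors. Nothing available explains why the step is this large.

The compounds shown leave open whether the stronger effect of compound 4 depends on the tert-butyl group or on having one aromatic ring rather than two. A 4-methylphenyl group at this position would help separate those two readings.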